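The source may report more compounds than this note shows. Statements on the series, on what has been measured and on what is new or still open speak of the compounds shown alone.

Measured so far:
compound 1, `COc1ccc2c(c1)CCC(C1CCC(O)C1(C)C)C2`, 1.5 mg/kg
compound 2, `C#C[C@]1(O)CCC(C2CCc3cc(O)ccc3C2)C1(C)C`, 0.025 mg/kg

In a functional assay on the whole organism with Rattus norvegicus as the target (on this read-out higher numbers stand for an effect only at larger amounts of compound and lower numbers for an effect already at smaller amounts), compound 2 gives 0.025 mg/kg, the lowest of the two numbers. Compound 1, which carries a methoxy on the aromatic ring and a plain hydroxyl on the five-membered ring, gives 1.5 mg/kg, a higher number that lies well beyond the scatter of repeated measurements. Compound 1 and compound 2 differ in more than one place, so their gap cannot be assigned to a single change.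

Compound 3, `C#C[C@]1(O)CCC(C2CCc3cc(OC)ccc3C2)C1(C)C`, has not been measured in this assay. It differs from compound 2 in one place only: methyl in place of hydrogen on an oxygen on an aromatic ring, read one bond further out as hydroxy to methoxy. The ethynyl carbinol of compound 2 is kept. Among the measured compounds shown here, no single-change step between measured compounds is available to calibrate this change, so its size has to be judged from the two values alone. Compound 1 shows that a methoxy on this core is compatible with activity in this assay, though at a higher dose. The step from compound 2 to compound 3 is expected to be a modest rise, a 2.4-fold higher number from compound 2 to compound 3 (0.38 log units; beyond the scatter), beyond the scatter but far from the gap to compound 1. For compound 3 the minimum effective dose is estimated at 0.06 mg/kg, within 0.02 mg/kg to 0.25 mg/kg.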

Compound 3, minimum effective dose: 0.025 mg/kg
For compound 3 the middle estimate is 2.4-fold (0.38 log units) above the measured one; the range from low to high includes it.
By their numbers in this assay, from the lowest: compounds 2 and 3 (each within the scatter of the next); then compound 1.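

In this assay, among the compounds shown here, the change on the oxygen on an aromatic ring can now be read on its own for the first time: methyl in place of hydrogen gives no change at the digits printed from compound 2 to compound 3 (within the scatter), with the ethynyl carbinol kept on both sides. The hydrogen on this oxygen is therefore not needed for the read-out in this pair, and hydroxy and methoxy cannot be told apart here within the scatter. Compound 1 could not show this, since it differs from compound 2 in more than one place and its methoxy could not be separated from its other difference. Nothing among the data shown bears on what lies behind this result.

The compounds shown leave open whether a larger group on the same oxygen, such as ethyl or a longer chain, would read the same way, or whether an amine in place of the hydroxy would. For the compounds shown here, they also leave open whether methyl in place of hydrogen on this oxygen has so small an effect when the ethynyl carbinol is absent, as no pair shows that change on such a compound.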